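Fluorine position shift in a small anticonvulsant series

The source may hold more compounds than are shown below. What is called first, only, known or untested is meant among the compounds shown, and "the series" means these compounds.

Of the compounds shown here, three have been tested in a functional assay on the whole organism (strain Swiss) with Mus musculus as the target, in the maximal electroshock model, with a stated time of 2 h, at a dose of 300 mg/kg by the intraperitoneal route; on this read-out higher numbers stand for a stronger effect at the one dose given and lower numbers for a weaker effect. Compound 1 `CCC(C(=O)N1CCN(c2cccc(OC)c2)CC1)N1C(=O)CCC1=O` gives 0%, and compound 3 `CCC(C(=O)N1CCN(c2ccc(C(F)(F)F)cc2)CC1)N1C(=O)CCC1=O` gives 0%. Compound 2 `CC(C(=O)N1CCN(c2ccccc2F)CC1)N1C(=O)CCC1=O` gives 25%, the highest of the three numbers, and its gap to compound 1 and to compound 3 lies beyond the scatter. Compound 4 `CC(C(=O)N1CCN(c2ccc(F)cc2)CC1)N1C(=O)CCC1=O` has not yet been measured. It differs from compound 2 in one place: 4-fluorophenyl in place of 2-fluorophenyl on an amine nitrogen in a ring. Among the compounds with values here, no step between two measured compounds bears on this change, so the expectation rests on compound 2 alone. The step of a number 5 percentage points lower from compound 2 to compound 4 (within the scatter) is expected to be small, within or near the scatter, with a slight downward lean. Compound 4 is expected to give 20%, with a range from 0% to 50%.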

Compound 4, a percentage reported as activity, at one dose (the size of the read-out at that dose, not a potency): 50%
Estimate against measurement, compound 4: 30 percentage points below, within the range that was stated.
By their numbers in this assay, from the lowest: compounds 1 and 3 (each within the scatter of the next); then compound 2; then compound 4.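

In this assay, 4-fluorophenyl in place of 2-fluorophenyl on the amine nitrogen in a ring gives a number 25 percentage points higher from compound 2 to compound 4 (beyond the scatter). The earlier compounds shown here offered no step at this place; this one shows that the read-out at the single dose responds to where the fluorine sits, with the same atoms and the same counts on both sides. Nothing available explains the step. Going by these compounds, it remains open whether chlorine in place of the fluorine in 4-fluorophenyl keeps the read-out of compound 4 at 50%.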